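Working notes: ring-nitrogen substituent, compound 1 to compound 4

This account rests on a few compounds, and the source may have more. Where it says the series, first, only, none or still open, it means among the compounds named here.

The series shares one core, seen in compound 1 `NC(=O)c1c(NC(=O)c2ccccc2Cl)sc2c1CCN(Cc1cc(Cl)cc(Cl)c1)C2`. In a functional assay on HL-60 cells (Homo sapiens) for antiproliferative activity, with a stated time of 24 h (on this read-out lower numbers stand for stronger inhibition and higher numbers for weaker inhibition), compound 1 gives 15800 nM, the lowest of the two plain numbers, though compound 3 `NC(=O)c1c(NC(=O)c2cccc([N+](=O)[O-])c2)sc2c1CCN(Cc1ccc(Cl)cc1Cl)C2` sits close: in this assay compound 3 gives 19800 nM, a gap within the scatter, so neither is called the stronger. Compound 2 `NC(=O)c1c(NC(=O)c2ccc(C(F)(F)F)cc2)sc2c1CCN(Cc1ccccc1F)C2` is reported only as a limit of the assay: in this assay compound 2 gives > 50000 nM. That limit, (the limit of > 50000 nM in this assay, at which 1 of the 3 values shown sits), means one member of the three has no plain number. Among the measured compounds shown here, no two measured compounds differ in a single place, so no measured step is available.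

Compound 4 `CSc1ccccc1NC(=S)N1CCc2c(sc(NC(=O)c3ccccc3Cl)c2C(N)=O)C1` differs from compound 1 on the amine nitrogen in a ring: a group of 11 heavy atoms (8 carbon, 1 nitrogen, 2 sulfur; one six-membered aromatic ring of carbon only) in place of a group of 9 heavy atoms (7 carbon, 2 chlorine; one six-membered aromatic ring of carbon only), on an amine nitrogen in a ring. The entering group carries one hydrogen-bond donor and two hydrogen-bond acceptors, where the leaving 3,5-dichlorobenzyl carries none.

Without a measured single-point step, the expectation in this assay is a small move only, not clearly beyond the scatter, given that compound 1 at 15800 nM already sits at the weak end. Compound 4 is therefore estimated at 18000 nM, with a range from 5000 nM to 50000 nM. The expected step is a 1.1-fold higher number from compound 1 to compound 4 (0.06 log units; within the scatter), essentially none beyond the scatter. A limit-only result is also a real possibility.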

Compound 4, half-maximal inhibitory concentration: 14600 nM
The estimate for compound 4 lay 1.2-fold (0.09 log units) above the measured number; measured number inside the range.
By their numbers in this assay, from the lowest: compounds 4, 1 and 3 (each within the scatter of the next). At a limit, above all of these: compound 2.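

Among the compounds shown here, the step on the amine nitrogen in a ring is the first single-place comparison, and in this assay it reads a 1.1-fold lower number from compound 1 to compound 4 (0.03 log units; within the scatter). The 3,5-dichlorobenzyl group, with no hydrogen-bond donors or acceptors, can therefore give way on this nitrogen to the larger entering group, with its hydrogen-bond donor, hydrogen-bond acceptors and double bond outside aromatic rings, without a move beyond the scatter, at least with the rest of compound 1 held fixed. This is one pair only, so it shows tolerance of this single change and not a trend across the position, and no measured property bears on why the two groups read alike.

Open, as far as these compounds go, is whether a group on this nitrogen without an aromatic ring, such as a plain methyl, an acetyl or a dimethylaminoethyl chain, would move the number beyond the scatter, and whether the same tolerance holds when the rest of the molecule differs, as it does in compound 3. Compound 2 differs from the others in more than one place and stands only as a limit, so it says nothing about this position: the limit of > 50000 nM in this assay, at which 1 of the 4 values shown sits.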